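A few compounds are considered here, and "the series" means these few. Any claim that something is new, unique, unknown or untested is made for them only; others in the source may bear on it.

Of the compounds shown here, three built on one shared core have been measured in a functional assay on KB cells (Homo sapiens) for cytotoxicity, read by resazurin assay, with a stated time of 3 days; a higher number here means a weaker inhibitor, a lower number a stronger inhibitor. Compound 1 `CCCCCCC(=O)NCC(C)(C)CC1=C(O)C(=O)c2ccccc2C1=O` gives 28200 nM. Compound 2 `CCCCCCCC(=O)NCC(C)(C)CC1=C(O)C(=O)c2ccccc2C1=O` gives 24600 nM, and compound 3 `CCCCCCCCCCC(=O)NCC(C)(C)CC1=C(O)C(=O)c2ccccc2C1=O` gives 17600 nM. Compound 3 thus carries the lowest of the three numbers, but its separation from each neighbour stays within the scatter: a 1.4-fold lower number from compound 2 to compound 3 (0.15 log units; within the scatter) and a 1.6-fold lower number from compound 1 to compound 3 (0.20 log units; within the scatter). Compound 4 `CCCCCCCCCCCCCC(=O)NCC(C)(C)CC1=C(O)C(=O)c2ccccc2C1=O` continues the same series of chain extensions, with propyl in place of hydrogen on a saturated chain carbon, ten or more bonds along the chain from a carbonyl carbon. The three measured steps that bear on this change are all chain lengthenings of the same kind: a 1.1-fold lower number from compound 1 to compound 2 (0.06 log units; within the scatter), a 1.6-fold lower number from compound 1 to compound 3 (0.20 log units; within the scatter) and a 1.4-fold lower number from compound 2 to compound 3 (0.15 log units; within the scatter), each of them within the scatter, though all pointing toward lower numbers as the chain grows. On that basis a small further lowering is expected for compound 4, so that its step is estimated as a 1.5-fold lower number from compound 3 to compound 4 (0.17 log units; within the scatter), and its value in this assay is expected to be 12000 nM, within a range from 5000 nM to 30000 nM.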

Compound 4, half-maximal inhibitory concentration: 25100 nM
The estimate for compound 4 lay 2.1-fold (0.32 log units) below the measured number; the measured number falls inside the stated range.
By their numbers in this assay, from the lowest: compounds 3, 2, 4 and 1 (each within the scatter of the next).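

In this assay propyl in place of hydrogen on a saturated chain carbon, ten or more bonds along the chain from a carbonyl carbon, gives a 1.4-fold higher number from compound 3 to compound 4 (0.15 log units; within the scatter) and so differs in sign from the three earlier steps, which all printed lower numbers. Hexyl at seven bonds along the chain from a carbonyl carbon gives a 1.0-fold higher number from compound 2 to compound 4 (0.01 log units; within the scatter) and heptyl at six bonds along the chain gives a 1.1-fold lower number from compound 1 to compound 4 (0.05 log units; within the scatter) and neither of these steps leaves the scatter. Across all four compounds, no chain lengthening produces a step beyond the scatter, and the direction shared by the earlier steps does not hold for compound 4.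

On these data alone, whether a longer chain, an amine or a carboxylic acid at this place would give a step beyond the scatter in this assay remains open. No evidence is available here that bears on this result.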